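The source may hold more compounds than are shown below. What is called first, only, known or untested is meant among the compounds shown, and "the series" means these compounds.

Of the compounds shown here, three that share one core have been tested in a functional assay on TSGH 9201 cells (Homo sapiens) for cytotoxicity; a lower number here means a stronger inhibitor, a higher number a weaker inhibitor. Compound 1 `COc1ccc(S(=O)(=O)N2CCc3cccc(NC(=O)c4ccncc4)c32)cc1` gives 10.8 nM. Compound 2 `COc1ccc(S(=O)(=O)N2CCc3cccc(NC(=O)c4ccco4)c32)cc1` gives 11.1 nM, and the step of a 1.0-fold higher number from compound 1 to compound 2 (0.01 log units; within the scatter) stays within the usual scatter, so the two cannot be told apart. Compound 3 `COc1ccc(S(=O)(=O)N2CCc3cccc(NC(C)=O)c32)cc1` gives 103 nM, the highest of the three numbers, which makes it the weakest inhibitor of the set: the steps of a 9.5-fold higher number from compound 1 to compound 3 (0.98 log units; beyond the scatter) and a 9.3-fold higher number from compound 2 to compound 3 (0.97 log units; beyond the scatter) both lie beyond the scatter. Compound 4 `COc1ccc(S(=O)(=O)N2CCc3cccc(NC(=O)c4ccccc4)c32)cc1` has not yet been measured. Its difference from compound 3 is phenyl in place of methyl on a carbonyl carbon, in other words the acetamido group becoming a benzamido group. The two measured steps that bear on this change are the ones in which pyridin-4-yl or furan-2-yl on that carbonyl carbon was exchanged for methyl, and both weakened inhibition by a modest amount. Going the other way, from methyl to phenyl on the same carbonyl carbon, a step of similar size but in the opposite direction is expected, although phenyl itself has not been tested in this series. For compound 4 the expected number in this assay is therefore 11 nM, with a likely range from 5 nM to 25 nM, corresponding to an expected step of a 9.4-fold lower number from compound 3 to compound 4 (0.97 log units; beyond the scatter).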

Compound 4, half-maximal inhibitory concentration: 201 nM
The estimate for compound 4 lay 18-fold (1.26 log units) below the measured number; the measured number lies above the stated range.
By their numbers in this assay, from the lowest: compounds 1 and 2 (each within the scatter of the next); then compounds 3 and 4 (each within the scatter of the next).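

In this assay, the step of a 2.0-fold higher number from compound 3 to compound 4 (0.29 log units; within the scatter) stays within the scatter, so on this carbonyl carbon phenyl and methyl cannot be told apart, and having a ring at this place does not by itself bring the number down. The choice of ring does matter here: the steps of an 18-fold higher number from compound 2 to compound 4 (1.26 log units; beyond the scatter) and a 19-fold higher number from compound 1 to compound 4 (1.27 log units; beyond the scatter) are both large and beyond the scatter, so the furan-2-yl and pyridin-4-yl amides separate clearly from the benzamido compound, even though all three carry an aromatic ring on the same carbonyl carbon. Nothing measured here explains why these rings differ.

Among these compounds, the two low numbers go with rings that contain an atom other than carbon, while the carbon-only phenyl ring sits with methyl, but two such rings are too few to show whether that atom is what counts, and a thiophen-2-yl or pyridin-3-yl ring would test the idea further. Also open, from the compounds shown here alone, is how a phenyl ring carrying an amine or a carboxylic acid, or a longer chain such as propyl, would behave on this carbonyl carbon.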